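The source may report more compounds than this note shows. Statements on the series, on what has been measured and on what is new or still open speak of the compounds shown alone.

Compound 1, `COc1ccc(/C=C2\CCC/C(=C\c3ccc(OC)c(OC)c3)C2=O)cc1`, is tested in a functional assay on SW-620 cells (Homo sapiens) for cytotoxicity, read by MTT assay, with a stated time of 72 h; a lower number here means a stronger inhibitor, a higher number a weaker inhibitor. Compound 1 gives 6600 nM, which is the highest of the two numbers shown, with compound 3, `COc1ccc(/C=C2\CCC/C(=C\c3ccc(OC)c(OC)c3)C2=O)cc1OC`, nearest at 4500 nM; the two lie within the scatter of each other. Compound 2, `COc1ccc(/C=C2\CCC/C(=C\c3ccc(OC)c(OC)c3)C2=O)c(OC)c1`, returns only a limit of the assay, > 20000 nM. The two measured steps are alike in kind: an at least 3.0-fold higher number from compound 1 to compound 2 (0.48 log units; beyond the scatter), and a 1.5-fold lower number from compound 1 to compound 3 (0.17 log units; within the scatter); in both a methoxy replaces a hydrogen on an aromatic carbon, and the first of them reaches (the limit of > 20000 nM in this assay, at which 1 of the 3 values shown sits).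

Compound 4, `COc1ccc(/C=C2\CCC/C(=C\c3ccc(O)c(O)c3)C2=O)cc1OC`, is yet to be measured. It differs from compound 1 by 3,4-dihydroxyphenyl in place of 4-methoxyphenyl on a double-bonded chain carbon bound to a double-bonded ring carbon. Neither measured step removes a methoxy or introduces a hydroxyl, so they bear on this change only loosely; they show that substitution on the aryl rings shifts this assay by modest amounts at most. A step of at most modest size is therefore expected, in no firm direction, a 1.3-fold lower number from compound 1 to compound 4 (0.12 log units; within the scatter). Compound 4 is estimated at 5000 nM, with a range from 1500 nM to 20000 nM.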

Compound 4, half-maximal inhibitory concentration: 10500 nM
Compound 4: middle estimate off by 2.1-fold (0.32 log units), on the low side; measured number inside the range.
By their numbers in this assay, from the lowest: compounds 3, 1 and 4 (each within the scatter of the next, the first and the last beyond it). At a limit, above all of these: compound 2.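

With this assay as the read-out, swapping the methoxy-bearing aryl group for the hydroxyl-bearing one gives a 1.6-fold higher number from compound 1 to compound 4 (0.20 log units; within the scatter), so this exchange produces no change that can be told from the scatter. The earlier compounds shown here carry only methoxy groups on their aryl rings, whereas compound 4 shows that a ring bearing hydroxyl groups, which are hydrogen-bond donors, can take this place and still give a number rather than a limit. Nothing measured here speaks to why the exchange has so little effect. The compounds shown leave open whether one hydroxyl alone would read like the pair, and which of the two matters more. They also leave open how an amine or a carboxylic acid on this ring would fare.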